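The compounds below may be only part of what the source reports. "The series", "measured", "known", "first", "only" and "open" are said of these compounds alone.

Working notes on the series. Compound 2 `[O-][n+]1nc(NCOC2CCCCC2)[n+]([O-])c2ccccc21` gives 3250 nM in a functional assay on PC-3 cells (Homo sapiens) for cytotoxicity, read by MTT assay, with a stated time of 72 h; on this read-out higher numbers stand for weaker inhibition and lower numbers for stronger inhibition; compound 1 `[O-][n+]1nc(NCOCc2ccc(Cl)cc2)[n+]([O-])c2ccccc21` gives 5760 nM in this assay. Compound 2 holds the smaller of the two numbers, but its gap to compound 1 is within the scatter, so the two compounds are not separated. For the measured compounds named here, no single-place step between measured compounds is available. Compound 3 `[O-][n+]1nc(NCOCc2ccccc2)[n+]([O-])c2ccccc21` differs from compound 2 by benzyl in place of cyclohexyl on an oxygen on a saturated carbon. On the two numbers shown, compound 3 is expected to stay within the scatter of compound 2, with a step of a 1.4-fold higher number from compound 2 to compound 3 (0.14 log units; within the scatter). The estimate for compound 3 in this assay is 4500 nM, with a range from 2000 nM to 10000 nM.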

Compound 3, half-maximal inhibitory concentration: 13400 nM
Estimate against measurement, compound 3: 3.0-fold (0.47 log units) below; the measured number lies above the stated range.
By their numbers in this assay, from the lowest: compounds 2 and 1 (each within the scatter of the next); then compound 3.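

Benzyl in place of cyclohexyl on the oxygen gives a 4.1-fold higher number from compound 2 to compound 3 (0.62 log units; beyond the scatter) in this assay, so this position separates two ring-bearing groups, which the earlier pair could not show. Hydrogen in place of chloro on an aromatic carbon gives a 2.3-fold higher number from compound 1 to compound 3 (0.37 log units; beyond the scatter), so the benzyl group also responds to a single change on its ring. Nothing available explains either step.

On these data alone, whether an amine or a longer chain on the oxygen would hold the number of compound 2 remains open. Also open, as far as these compounds go, is whether other groups in place of chloro on that aromatic carbon would follow compound 1.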